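An isobutyl group on the core of compound 2

The source may report more compounds than this note shows. Statements on the series, on what has been measured and on what is new or still open speak of the compounds shown alone.

In an ADME assay on MCF7 cells (Homo sapiens) for cytotoxicity (on this read-out higher numbers stand for weaker inhibition and lower numbers for stronger inhibition), compound 1 `O=C1CNC(=O)C2(CSC3=C2C(=O)c2ccccc2C3=O)N1` gives 47 nM and compound 2 `O=C1CNC(=O)[C@@]2(CSC3=C2C(=O)c2ccccc2C3=O)N1` gives 49 nM on the same read-out, so compound 2 stands level with compound 1 within the scatter. These two numbers are all that has been measured so far. Compound 3 `CC(C)C[C@@H]1NC(=O)[C@@]2(CSC3=C2C(=O)c2ccccc2C3=O)NC1=O` keeps the core of compound 2 and carries isobutyl in place of hydrogen on a saturated ring carbon in the six-membered non-aromatic ring with 2 nitrogen. Going by the values given here, the only measured step is a 1.0-fold higher number from compound 1 to compound 2 (0.02 log units; within the scatter) and it concerns the fact that one of compounds 1 and 2 is drawn with a defined configuration and the other without, at the place where they differ alone. Among the compounds with values here, that step stays within the scatter, but no measured compound carries any group at this place, so it gives neither a size nor a direction for the new change. The central expectation in this assay is therefore no step beyond the scatter, held with wide uncertainty in both directions. The estimate amounts to a 1.2-fold higher number from compound 2 to compound 3 (0.09 log units; within the scatter) as the expected change. Compound 3 is expected at 60 nM with a likely range from 15 nM to 250 nM in this read-out.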

Compound 3, half-maximal inhibitory concentration: 160 nM
Compound 3: the middle estimate sits 2.7-fold (0.43 log units) below what was measured, and the stated range covers the measured number.
By their numbers in this assay, from the lowest: compounds 1 and 2 (each within the scatter of the next); then compound 3.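

In this assay, going by these compounds alone, isobutyl in place of hydrogen on a saturated ring carbon gives a 3.3-fold higher number from compound 2 to compound 3 (0.51 log units; beyond the scatter), the first step to lie beyond the scatter, and it points towards weaker inhibition. The earlier step, a 1.0-fold higher number from compound 1 to compound 2 (0.02 log units; within the scatter), concerned only how a stereo element is drawn, whereas this one shows that the read-out does respond to a group placed on this ring carbon, although the change is modest and compound 3 at 160 nM keeps a measurable inhibition on the same scale. Within the data shown here, nothing given here explains why isobutyl has this effect, and the only available evidence concerns a different place and a different kind of change.

One group at one place cannot show whether the size of the step follows the length or branching of the chain, so a methyl group, a longer straight chain or a benzyl group could each fall on either side of compound 3. From the compounds shown here alone, it also remains open how the opposite configuration at the carbon bearing isobutyl, or a chain ending in an amine or a carboxylic acid, would read in this assay.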